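Shortening the Sulfanyl Chain: From Compound 2 to Compound 4

This account rests on a few compounds, and the source may have more. Where it says the series, first, only, none or still open, it means among the compounds named here.

Measured in a functional assay on PC-3 cells (Homo sapiens) for antiproliferative activity, read by MTT assay, with a stated time of 48 h; on this read-out higher numbers stand for weaker inhibition and lower numbers for stronger inhibition:
- compound 1 `COc1ccc(CN(C(=O)CSc2ccccn2)c2cc(OC)c(OC)c(OC)c2)cc1`: 7510 nM
- compound 2 `COc1ccc(CN(C(=O)CCSc2nc3ccccc3o2)c2cc(OC)c(OC)c(OC)c2)cc1`: 20200 nM
- compound 3 `COc1ccc(CN(C(=O)CCCCSc2nc3ccccc3o2)c2cc(OC)c(OC)c(OC)c2)cc1`: 45600 nM

Among these three, compound 2 at 20200 nM gives the second highest number, with compound 1 lower and compound 3 higher. The step to compound 4 `COc1ccc(CN(C(=O)CSc2nnnn2C)c2cc(OC)c(OC)c(OC)c2)cc1` is (1-methyl-1H-tetrazol-5-yl)sulfanyl in place of ((1,3-benzoxazol-2-yl)sulfanyl)methyl on a saturated chain carbon bound to a carbonyl carbon. Cut one bond further out, it reads 2-((1,3-benzoxazol-2-yl)sulfanyl)ethyl to ((1-methyl-1H-tetrazol-5-yl)sulfanyl)methyl.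

Among the compounds with values here, two measured steps bear on this change. The closer one is a 2.7-fold higher number from compound 1 to compound 2 (0.43 log units; beyond the scatter), since compound 1, like compound 4, has its sulfanyl group on a saturated chain carbon bound to a carbonyl carbon. The other is a 2.3-fold higher number from compound 2 to compound 3 (0.35 log units; beyond the scatter), where the chain grows. Within the data shown here, both are modest, but no measured compound carries the tetrazole, so this assay is expected to show only a small move towards a lower number, smaller than either measured step. The expected change is a 1.7-fold lower number from compound 2 to compound 4 (0.23 log units; within the scatter). Compound 4 is estimated at 12000 nM, with an expected range of 4000 nM to 36000 nM.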

Compound 4, half-maximal inhibitory concentration: 10500 nM
The estimate for compound 4 lay 1.1-fold (0.06 log units) above the measured number; measured number inside the range.
By their numbers in this assay, from the lowest: compounds 1, 4 and 2 (each within the scatter of the next, the first and the last beyond it); then compound 3.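

In this assay the exchange of ((1,3-benzoxazol-2-yl)sulfanyl)methyl for (1-methyl-1H-tetrazol-5-yl)sulfanyl on a saturated chain carbon bound to a carbonyl carbon gives a 1.9-fold lower number from compound 2 to compound 4 (0.28 log units; within the scatter) and so this position tolerates that change without a difference that can be told from the scatter. Likewise, 1-methyl-1H-tetrazol-5-yl in place of pyridin-2-yl on a sulfur gives a 1.4-fold higher number from compound 1 to compound 4 (0.15 log units; within the scatter) and so separates neither ring from the other. Nothing measured here accounts for either step.

Going by these compounds, it remains open how the 1-methyl-1H-tetrazol-5-yl group would read on the longer chains of compound 2 and compound 3. Also open, on these data alone, is whether the sulfur matters at all, as an amine or a carboxylic acid at this place would show.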